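The source may report more compounds than this note shows. Statements on the series, on what has been measured and on what is new or still open speak of the compounds shown alone.

Of the compounds shown here, three built on one shared core have been measured in a functional assay on isolated protein for inhibition of Glucose-dependent insulinotropic receptor (Rattus norvegicus), read by HTRF and cAMP accumulation; a lower number here means a smaller maximal response, a higher number a larger maximal response. Compound 1 `Cc1nc(S(C)(=O)=O)ccc1Oc1ncnc(OC2CCN(C(=O)OC3CCC3)CC2)c1F` gives 81%, compound 2 `Cc1nc(S(C)(=O)=O)ccc1Oc1ncnc(OC2CCN(C(=O)O[C@H](C)C(F)(F)F)CC2)c1F` gives 85%, and compound 3 `Cc1nc(S(C)(=O)=O)ccc1Oc1ncnc(OC2CCN(C(=O)SC(C)(C)C)CC2)c1F` gives 76%. Compound 2 holds the highest of the three numbers, but its separation from the others, a number 4 percentage points higher from compound 1 to compound 2 (within the scatter) and a number 9 percentage points lower from compound 2 to compound 3 (within the scatter), lies within the scatter, so the three compounds cannot be placed in any order.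

Compound 4 `Cc1nc(S(C)(=O)=O)ccc1Oc1ncnc(OC2CCN(C(=O)c3ncc(Cl)cn3)CC2)c1F` is the member not yet tested. Its difference from compound 2 is 5-chloropyrimidin-2-yl in place of 1-(trifluoromethyl)ethoxy on a carbonyl carbon. The measured steps that bear on this change all alter the group attached to that same carbonyl carbon: a number 4 percentage points higher from compound 1 to compound 2 (within the scatter), a number 5 percentage points lower from compound 1 to compound 3 (within the scatter) and a number 9 percentage points lower from compound 2 to compound 3 (within the scatter). Every one of them stays within the scatter, so the maximal response has so far been indifferent to what sits on the carbonyl. Going by the values given here, the entering group, however, brings an aromatic ring where the measured compounds carried only alkoxy or alkylsulfanyl groups, and no measured step covers such a change, which widens the uncertainty.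

Compound 4 is therefore expected to give about 80%, with a range from 60% to 95%. The expected step is a number 5 percentage points lower from compound 2 to compound 4 (within the scatter), which is anticipated to remain within the scatter.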

Compound 4, largest response reached (reported as efficacy), in percent of the reference or control that the assay uses: 77%
Compound 4: the middle estimate sits 3 percentage points above what was measured; the measured number falls inside the stated range.
By their numbers in this assay, from the lowest: compounds 3, 4, 1 and 2 (each within the scatter of the next).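

In this assay, the steps of a number 8 percentage points lower from compound 2 to compound 4 (within the scatter) and a number 4 percentage points lower from compound 1 to compound 4 (within the scatter) and a number 1 percentage points higher from compound 3 to compound 4 (within the scatter) all stay within the scatter, so 5-chloropyrimidin-2-yl on the carbonyl carbon cannot be told apart from the three groups it is compared with. This extends the earlier finding: the position had been shown to accept only groups joined through oxygen or sulfur, and it now also holds an aromatic ring with two hetero atoms and a chlorine, joined directly through carbon, while the maximal response stays in the same band. The loss of the defined stereocentre that leaves with 1-(trifluoromethyl)ethoxy also comes with no step beyond the scatter, and nothing available gives a reason for this indifference.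

With one aromatic group in hand, the share of the ring and the share of the chlorine cannot be separated, so a plain phenyl or an unsubstituted pyrimidin-2-yl would be needed to divide them. As far as these compounds go, it also stays open whether an amine on the carbonyl carbon, or a carboxylic acid on the aromatic ring, would keep the response within this band.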